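Acyloxy in place of methoxy on the shared core

The source may hold more compounds than are shown below. What is called first, only, known or untested is meant among the compounds shown, and "the series" means these compounds.

Going by the values given here, compound 1 `COc1cc(C(C)(C)C)ccc1C/N=C(\S)NCc1ccc(NS(C)(=O)=O)cc1` stands at the weaker end of the two measured members: in a functional assay for inhibition of Vanilloid receptor (Rattus norvegicus) (a lower number here means a stronger inhibitor, a higher number a weaker inhibitor), compound 1 gives 2400 nM, the highest of the two numbers. Among the compounds with values here, its nearest neighbour is compound 2 `CC(C)Oc1cc(C(C)(C)C)ccc1C/N=C(\S)NCc1ccc(NS(C)(=O)=O)cc1`, which in this assay gives 350 nM; the step of a 6.9-fold lower number from compound 1 to compound 2 (0.84 log units; beyond the scatter) is the only measured change at the oxygen on the aromatic ring. Compound 3 `CC(C)(C)C(=O)Oc1cc(C(C)(C)C)ccc1C/N=C(\S)NCc1ccc(NS(C)(=O)=O)cc1` differs from compound 1 by (tert-butyl)carbonyl in place of methyl on an oxygen on an aromatic ring. Within the data shown here, only the step from compound 1 to compound 2 bears on this change, and it exchanged methyl for isopropyl on the same oxygen; the (tert-butyl)carbonyl brings a carbonyl and an acceptor that isopropyl does not, so that step is an imperfect guide. A step in the same direction, smaller than the measured one, is expected: a 2.4-fold lower number from compound 1 to compound 3 (0.38 log units; beyond the scatter). Compound 3 is estimated at 1000 nM, within 250 nM to 4000 nM.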

Compound 3, half-maximal inhibitory concentration: 220 nM
Compound 3: the middle estimate sits 4.5-fold (0.66 log units) above what was measured; the measured number lies below the stated range.
By their numbers in this assay, from the lowest: compounds 3 and 2 (each within the scatter of the next); then compound 1.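

The oxygen on the aromatic ring accepts an acyl group as well as an alkyl group: in this assay, (tert-butyl)carbonyl in place of methyl gives a large step (an 11-fold lower number from compound 1 to compound 3 (1.04 log units; beyond the scatter)), so the gain over methyl is not confined to isopropyl. Against isopropyl, the same group gives no readable change (a 1.6-fold lower number from compound 2 to compound 3 (0.20 log units; within the scatter)), so the added carbonyl and its acceptor bring no separation between compound 2 and compound 3 in this assay. Nothing at hand explains why these two different groups read alike.

Still open, as far as these compounds go, is whether a smaller acyl group such as acetyl, or a benzoyl group, matches the (tert-butyl)carbonyl on this oxygen. Also open, from the compounds shown here alone, is how a free hydroxyl, a longer straight alkyl chain or a chain ending in an amine would read at the same place.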